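Swapping a pyrazole for a fluorophenyl on the shared core

The compounds below may be only part of what the source reports. "The series", "measured", "known", "first", "only" and "open" are said of these compounds alone.

Compound 1 `CN(C)CCCCN(C(=O)O)c1ccc(Cn2nc(-c3ccc(F)cc3)c3ccccc3c2=O)cc1`: 19000 nM
Compound 2 `CC(c1ccc(N(CCCCN(C)C)C(=O)O)cc1)n1nc(-c2ccc(F)cc2)c2ccccc2c1=O`: 15200 nM
Compound 3 `CN(C)CCCCOC(=O)Nc1ccc(Cn2nc(-c3cnn(C)c3)c3ccccc3c2=O)cc1`: 55900 nM

Three compounds were tested in an ADME assay on Huh-7 cells (Homo sapiens) for cytotoxicity, read by MTT assay, with a stated time of 48 h; on this read-out higher numbers stand for lower toxicity in this test and lower numbers for higher toxicity in this test. Compound 3 stands highest of the three, giving 55900 nM; compound 1 gives 19000 nM and compound 2 gives 15200 nM, both well beyond the scatter from compound 3. For the measured compounds named here, the only single-point step among the measured compounds, a 1.3-fold lower number from compound 1 to compound 2 (0.10 log units; within the scatter), touches a chain carbon far from the site that changes here and therefore says nothing direct about the step to compound 4 `CN(C)CCCCOC(=O)Nc1ccc(Cn2nc(-c3ccccc3F)c3ccccc3c2=O)cc1`, in which (2-fluorophenyl in place of 1-methyl-1H-pyrazol-4-yl on an aromatic carbon). Going by the values given here, compounds 1 and 2, which carry a fluorine-bearing phenyl ring rather than the pyrazole, both sit lower than compound 3, though each also differs from it in the linker, so no clean step exists. On that basis compound 4 is expected to move somewhat lower, by about a 2.0-fold lower number from compound 3 to compound 4 (0.30 log units; within the scatter), with wide uncertainty. Compound 4 is therefore estimated at 28000 nM, between 12000 nM and 60000 nM.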

Compound 4, half-maximal cytotoxic concentration: 52500 nM
Estimate against measurement, compound 4: 1.9-fold (0.27 log units) below; measured number inside the range.
By their numbers in this assay, from the lowest: compounds 2 and 1 (each within the scatter of the next); then compounds 4 and 3 (each within the scatter of the next).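

Putting 2-fluorophenyl in place of 1-methyl-1H-pyrazol-4-yl on the aromatic carbon next to the ring nitrogen gives a 1.1-fold lower number from compound 3 to compound 4 (0.03 log units; within the scatter) in this assay. For the compounds shown here, this is the first direct reading at this position, and it shows that a six-membered aromatic ring of carbon only and a five-membered aromatic ring with 2 hetero atoms cannot be told apart here, with the rest of the molecule held the same. No supporting measurement is available to explain this result.

As far as these compounds go, whether the position would read the same with a different kind of group, such as an amine, a carboxylic acid or a plain phenyl ring, remains open. Also open, from the compounds shown here alone, is whether the same swap would read alike on the linker of compound 1.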